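Bromo in place of benzyloxy on the shared core

The source may hold more compounds than are shown below. What is called first, only, known or untested is meant among the compounds shown, and "the series" means these compounds.

Compound 1 `Cc1ccc(S(=O)(=O)n2cc(-c3cc(C(F)(F)F)ccn3)c3ccccc32)cc1`: 29.2%
Compound 2 `Cc1ccc(S(=O)(=O)n2cc(-c3cc(C(F)(F)F)ccn3)c3cc(OCc4ccccc4)ccc32)cc1`: 23.2%

In a functional assay on A549 cells (Homo sapiens) for inhibition, tested at 1 uM (on this read-out lower numbers stand for a weaker effect and higher numbers for a stronger effect at the one concentration tested), compound 2 gives 23.2% and stands lowest of the two measured compounds; its nearest neighbour is compound 1, and the step of a number 6 percentage points lower from compound 1 to compound 2 (within the scatter) lies within the scatter. Compound 3 `Cc1ccc(S(=O)(=O)n2cc(-c3cc(C(F)(F)F)ccn3)c3cc(Br)ccc32)cc1` differs from compound 2 by bromo in place of benzyloxy on an aromatic carbon. Among the measured compounds shown here, only the step from compound 1 to compound 2 bears on this change, and it stayed within the scatter, so no step beyond the scatter is expected here. Compound 3 is therefore estimated at 27%, between 10% and 45%, a step of a number 3.8 percentage points higher from compound 2 to compound 3 (within the scatter) that is expected to remain within the scatter.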

Compound 3, a percentage reported as inhibition, at one concentration (the size of the read-out at that concentration, not a potency): 32.8%
The estimate for compound 3 lay 5.8 percentage points below the measured number; the measured number falls inside the stated range.
By their numbers in this assay, from the lowest: compounds 2, 1 and 3 (each within the scatter of the next).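

In this assay, the change at this aromatic carbon spans a wide range of size without moving the read-out clearly: the result is a number 9.6 percentage points higher from compound 2 to compound 3 (within the scatter), and against the unsubstituted core it is a number 3.6 percentage points higher from compound 1 to compound 3 (within the scatter). Hydrogen, bromo and benzyloxy therefore cannot be told apart at this position in this read-out. Nothing available explains this closeness. Going by these compounds, whether an amine or a carboxylic acid at this position would give a step beyond the scatter remains open. So does whether these three compounds would separate at another concentration.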